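Carbamate to sulfonamide on the amine nitrogen of compound 3

A few compounds are considered here, and "the series" means these few. Any claim that something is new, unique, unknown or untested is made for them only; others in the source may bear on it.

Compound 3 `COC(=O)NCC1Cc2ccc(NC(=O)c3cccc(C)c3-c3ccc(Cl)cc3)cc2C1` gives 8.7 nM in an assay for inhibition of apolipoprotein B-100 (Homo sapiens), tested at 100 nM; a higher number here means a weaker inhibitor, a lower number a stronger inhibitor. Among the three measured compounds it holds the highest number. Compound 1 `Cc1cccc(C(=O)Nc2ccc3c(c2)CC(NS(C)(=O)=O)C3)c1-c1ccc(Cl)cc1` gives 6.6 nM in this assay, and the step of a 1.3-fold higher number from compound 1 to compound 3 (0.12 log units; within the scatter) stays within the scatter. Compound 2 `COC(=O)NCC1Cc2ccc(NC(=O)c3cccc(C)c3-c3ccc(C(F)(F)F)cc3)cc2C1` gives 4.1 nM in this assay, and the step of a 2.1-fold higher number from compound 2 to compound 3 (0.33 log units; beyond the scatter) is modest but beyond the scatter.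

Compound 4 `Cc1cccc(C(=O)Nc2ccc3c(c2)CC(CNS(C)(=O)=O)C3)c1-c1ccc(Cl)cc1` differs from compound 3 in one place: methylsulfonyl in place of methoxycarbonyl on an amine nitrogen. The measured step that bears on this is a 1.3-fold higher number from compound 1 to compound 3 (0.12 log units; within the scatter), where methanesulfonamido on a saturated ring carbon gave way to ((methoxycarbonyl)amino)methyl and the number stayed within the scatter. The step of a 2.1-fold higher number from compound 2 to compound 3 (0.33 log units; beyond the scatter) concerns the aromatic substituent and does not bear on the present change. For the measured compounds named here, no measured pair separates the sulfonamide from the carbamate on the same chain, so the expectation rests on the single sulfonamide-to-carbamate comparison. Compound 4 is therefore expected in this assay to show a 1.2-fold lower number from compound 3 to compound 4 (0.06 log units; within the scatter), with an estimate of 7.5 nM, range 3.5 nM to 16 nM.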

Compound 4, half-maximal inhibitory concentration: 16 nM
Compound 4: the middle estimate sits 2.1-fold (0.33 log units) below what was measured; low and high end bracket the measured number.
By their numbers in this assay, from the lowest: compounds 2, 1, 3 and 4 (each within the scatter of the next, the first and the last beyond it).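

With the chain held fixed, methylsulfonyl in place of methoxycarbonyl on the amine nitrogen gives a 1.8-fold higher number from compound 3 to compound 4 (0.26 log units; within the scatter) in this assay, so this direct comparison does not separate the two groups. The chain length does register on the sulfonamide side: (methanesulfonamido)methyl in place of methanesulfonamido on a saturated ring carbon gives a 2.4-fold higher number from compound 1 to compound 4 (0.38 log units; beyond the scatter), a modest step beyond the scatter that the earlier comparison of compound 1 with compound 3, where both features changed at once, could not isolate. Nothing on hand accounts for this step.

Open, from the compounds shown here alone, is whether a free amine, an acetamide or a urea on the same nitrogen, or a longer chain, would give a larger step. Also open, going by these compounds, is whether trifluoromethyl in place of chloro would carry over to the sulfonamide of compound 4.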